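Capping the ring hydroxyl: from compound 2 to compound 4

A few compounds are considered here, and "the series" means these few. Any claim that something is new, unique, unknown or untested is made for them only; others in the source may bear on it.

Measured compounds:
- compound 1, `CC(C)=CCC1Cc2c(O)cc(=O)n(CCCO)c2CC1(C)C`: 25.6%
- compound 2, `CC(C)=CCC/C(C)=C/CC1Cc2c(O)cc(=O)n(CCCO)c2CC1(C)C`: 28.7%
- compound 3, `CC(C)=CCC1Cc2c(OC(=O)Nc3cccc(F)c3)cc(=O)n(CCCO)c2CC1(C)C`: 66.1%

All three were tested in a functional assay on PANC-1 cells (Homo sapiens) for inhibition, read by MTT assay, with a stated time of 24 h, tested at 10 uM; on this read-out higher numbers stand for more inhibition at the one concentration tested (going by the name of the read-out) and lower numbers for less inhibition. Compound 2 stands second of the three numbers: its nearest neighbour is compound 1, and the step of a number 3.1 percentage points higher from compound 1 to compound 2 (within the scatter) lies within the scatter, so the two cannot be told apart. Compound 3 stands far above, and the step of a number 40.5 percentage points higher from compound 1 to compound 3 (beyond the scatter) is large.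

Compound 4, `CC(C)=CCC/C(C)=C/CC1Cc2c(OCc3ccccc3)cc(=O)n(CCCO)c2CC1(C)C`, is not yet measured. It differs from compound 2 in one place: benzyl in place of hydrogen on an oxygen on an aromatic ring. Among the measured compounds shown here, the only measured step touching this oxygen is the one from compound 1 to compound 3, where a (3-fluorophenyl)carbamoyl entered on it and the number rose a great deal. A benzyl is a different group, so that step is only a rough guide, but it is the one that bears on the change. A rise in this assay is therefore expected for compound 4, estimated as a number 16.3 percentage points higher from compound 2 to compound 4 (beyond the scatter), giving 45% with a range from 25% to 68%.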

Compound 4, a percentage reported as inhibition, at one concentration (the size of the read-out at that concentration, not a potency): 46.5%
Beside the measured number, compound 4's estimate is 1.5 percentage points below it, and the stated range covers the measured number.
By their numbers in this assay, from the lowest: compounds 1 and 2 (each within the scatter of the next); then compound 4; then compound 3.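

In this assay, the change from hydroxy to benzyloxy gives a number 17.8 percentage points higher from compound 2 to compound 4 (beyond the scatter), so a free hydrogen on this oxygen is not required for the number to rise. Among the compounds shown here, until now, the only capped example carried a (3-fluorophenyl)carbamoyl on the core of compound 1; here a benzyl, made of carbon only and with 0 hydrogen-bond donors and 0 hydrogen-bond acceptors, gives a rise on the core of compound 2. Nothing measured here explains why capping this oxygen raises the number.

From the compounds shown here alone, it remains open whether a simple methyl on this oxygen would also raise the number, or whether an amine or a carboxylic acid on the benzyl ring would shift it. Compound 3 and compound 4 differ in more than one place, so the two capping groups still need comparing on one shared core.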